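The compounds below may be only part of what the source reports. "The series", "measured", "known", "first", "only" and "open" are said of these compounds alone.

Working notes on the series. In an in vitro ADME assay on microsomes from liver (Macaca fascicularis) for metabolic stability (a higher number here means faster removal of the compound, a lower number slower removal), compound 3 (`CC[C@H](C)[C@@H]1C(=O)N[C@H](C2Cc3ccccc3C2)C(=O)N1[C@@H](C(=O)N(C)C)c1ccc(C)nc1C`) gives 14 mL.min-1.g-1 and sits level with compound 1 (`CC[C@H](C)[C@@H]1C(=O)N[C@H](C2Cc3ccccc3C2)C(=O)N1[C@@H](C(=O)N1CCOCC1)c1cnc(C)cc1C`) at 16 mL.min-1.g-1 within the usual scatter. Set against compound 3, compound 2 (`Cc1ccc([C@H](C(=O)N(C)C)N2C(=O)[C@@H](C3Cc4ccccc4C3)NC(=O)[C@H]2CC(C)C)cn1`) stands far off at 21000 mL.min-1.g-1 and lies well beyond the scatter. These three compounds differ from one another in more than one place, so they offer no clean single change to read.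

Compound 4 (`CC[C@H](C)[C@@H]1C(=O)N[C@H](C2Cc3ccccc3C2)C(=O)N1[C@@H](C(=O)N(C)C)c1ccc(C)[n+]([O-])c1`) is still to be measured in this assay and departs from compound 3 in one place only: a group of 8 heavy atoms (6 carbon, 1 nitrogen, 1 oxygen; one six-membered aromatic ring with 1 hetero atom) in place of a group of 8 heavy atoms (7 carbon, 1 nitrogen; one six-membered aromatic ring with 1 hetero atom), on a saturated chain carbon bound to an amide-type nitrogen in a ring and a carbonyl carbon. The 2,6-dimethylpyridin-3-yl group is the part that leaves, on a saturated chain carbon bound to an amide-type nitrogen in a ring and a carbonyl carbon.

The closest guide is the pair of compound 1 at 16 mL.min-1.g-1 and compound 3 at 14 mL.min-1.g-1, while compound 2 at 21000 mL.min-1.g-1 goes against any reading of the series as uniformly slow to clear. The expected step of a 1.6-fold lower number from compound 3 to compound 4 (0.19 log units; within the scatter) is estimated to lean slightly towards slower removal and to stay within the scatter. For compound 4 the estimated value is 9 mL.min-1.g-1 with an expected range from 3 mL.min-1.g-1 to 35 mL.min-1.g-1 (a deliberately wide estimate).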

Compound 4, intrinsic clearance in microsomes: 1 mL.min-1.g-1
Beside the measured number, compound 4's estimate is 9.0-fold (0.95 log units) above it; the measured number lies below the stated range.
By their numbers in this assay, from the lowest: compound 4; then compounds 3 and 1 (each within the scatter of the next); then compound 2.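

In this assay, replacing the 2,6-dimethylpyridin-3-yl group with the group of 6 carbon, 1 nitrogen and 1 oxygen atoms, on a saturated chain carbon bound to an amide-type nitrogen in a ring and a carbonyl carbon, gives a 14-fold lower number from compound 3 to compound 4 (1.15 log units; beyond the scatter). Going by these compounds alone, this is the first change in one place that can be read, and it shows that the number responds strongly to the group at this position, even though both groups have the same heavy-atom count, one six-membered aromatic ring with 1 hetero atom, the same donor and acceptor counts and no net charge. No measurement shown here accounts for the size of this step.

The exchange removes a carbon and adds an oxygen in a single step, so the compounds shown do not separate the contribution of either atom, and one pair cannot establish a trend at this position. From the compounds shown here alone, it also remains open whether a phenyl or a pyrimidin-5-yl group on the same saturated chain carbon, or a carboxylic acid on that ring, would move the number in the same direction.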